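This account rests on a few compounds, and the source may have more. Where it says the series, first, only, none or still open, it means among the compounds named here.

Measured so far:
- compound 1 `O=[N+]([O-])c1cccc(-c2nn(-c3ccccc3)cc2C(Nc2nc3ccccc3s2)c2c(O)ccc3ccccc23)c1` with 32000 nM
- compound 2 `Cc1cccc(-c2nn(-c3ccccc3)cc2C(Nc2nc3ccccc3s2)c2c(O)ccc3ccccc23)c1` with 18500 nM

Among the measured compounds shown here, in a functional assay on A549 cells (Homo sapiens) for antiproliferative activity, read by MTT assay, with a stated time of 48 h (on this read-out higher numbers stand for weaker inhibition and lower numbers for stronger inhibition), compound 1 gives 32000 nM and stands within the scatter of compound 2, the only other measured compound. Compound 3 `O=[N+]([O-])c1cccc(-c2nn(-c3ccccc3)cc2C(Nc2nc3ccc(Cl)cc3s2)c2c(O)ccc3ccccc23)c1` differs from compound 1 by chloro in place of hydrogen on an aromatic carbon with chloro in place of hydrogen on an aromatic carbon. For the measured compounds named here, no measured step covers this change. Going by the values given here, the one available step, a 1.7-fold lower number from compound 1 to compound 2 (0.24 log units; within the scatter) for methyl in place of nitro, lies at another place and stays within the scatter, so no step beyond the scatter is expected in this assay here. The expected step is a 1.3-fold lower number from compound 1 to compound 3 (0.11 log units; within the scatter) and it remains within the scatter. For compound 3 the estimated value is 25000 nM with an expected range from 10000 nM to 55000 nM as the likely span.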

Compound 3, half-maximal inhibitory concentration: 42500 nM
The estimate for compound 3 lay 1.7-fold (0.23 log units) below the measured number; the range from low to high includes it.
By their numbers in this assay, from the lowest: compounds 2, 1 and 3 (each within the scatter of the next, the first and the last beyond it).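

In this assay, among the compounds shown here, 1,3-benzothiazol-2-yl to 6-chloro-1,3-benzothiazol-2-yl gives a 1.3-fold higher number from compound 1 to compound 3 (0.12 log units; within the scatter), the first reading at this position of the series. Chloro here therefore leaves compound 3 within the scatter of compound 1, so this position, like the methyl-for-nitro place, has shown no step beyond the scatter so far. No measured evidence is available to explain this result.

Open, from the compounds shown here alone, is whether an amine or a carboxylic acid at this position would move the number beyond the scatter. Also open, going by these compounds, is whether chloro here would give the same result with methyl in place of nitro.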